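Pendant phenyl substituent removal in a cytotoxicity series

A few compounds are considered here, and "the series" means these few. Any claim that something is new, unique, unknown or untested is made for them only; others in the source may bear on it.

Measured so far:
compound 1 `COc1ccc(-c2ccnc(C(=O)Nc3ccc(Oc4ccnc5[nH]ccc45)cc3)c2)cc1` — in a functional assay on PC-3 cells (Homo sapiens) for cytotoxicity, read by MTT assay, with a stated time of 72 h (a higher number here means a weaker inhibitor, a lower number a stronger inhibitor), compound 1 gives 9620 nM
compound 2 `O=C(Nc1ccc(Oc2ccnc3[nH]ccc23)cc1)c1cc(-c2ccc(Cl)cc2)ccn1` — compound 2 gives 25100 nM
compound 3 `Cc1cccc(-c2ccnc(C(=O)Nc3ccc(Oc4ccnc5[nH]ccc45)cc3)c2)c1` — compound 3 gives 5470 nM

Compound 3 stands at the low end of the three numbers: its separation from compound 1 (a 1.8-fold lower number from compound 1 to compound 3 (0.25 log units; within the scatter)) is within the scatter, while that from compound 2 (a 4.6-fold lower number from compound 2 to compound 3 (0.66 log units; beyond the scatter)) is beyond it. Compound 4 `O=C(Nc1ccc(Oc2ccnc3[nH]ccc23)cc1)c1cc(-c2ccccc2)ccn1` differs from compound 3 by hydrogen in place of methyl on an aromatic carbon. Going by the values given here, the steps that bear on this are the two at the same pendant ring, a 1.8-fold lower number from compound 1 to compound 3 (0.25 log units; within the scatter) and a 4.6-fold lower number from compound 2 to compound 3 (0.66 log units; beyond the scatter), modest at most; the step of a 2.6-fold higher number from compound 1 to compound 2 (0.42 log units; beyond the scatter) swaps two groups neither of which is present here. Little change beyond the scatter is expected in this assay, a 1.3-fold higher number from compound 3 to compound 4 (0.11 log units; within the scatter). Compound 4 is therefore estimated at 7000 nM, in the range 3000 nM to 16000 nM.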

Compound 4, half-maximal inhibitory concentration: 3270 nM
Compound 4: middle estimate off by 2.1-fold (0.33 log units), on the high side, within the range that was stated.
By their numbers in this assay, from the lowest: compounds 4, 3 and 1 (each within the scatter of the next, the first and the last beyond it); then compound 2.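

In this assay the unsubstituted phenyl gives the series a reference point: a 1.7-fold lower number from compound 3 to compound 4 (0.22 log units; within the scatter) shows no readable effect of removing the methyl, whereas a 7.7-fold lower number from compound 2 to compound 4 (0.89 log units; beyond the scatter) and a 2.9-fold lower number from compound 1 to compound 4 (0.47 log units; beyond the scatter) show that chloro and methoxy each sit at a higher number than hydrogen. None of the three substituents shown lowers the number beyond the scatter relative to hydrogen. No measurement on hand accounts for these steps.

Still open, from the compounds shown here alone, is whether an amine or a carboxylic acid on this ring would bring the number below that of compound 4. Also open, going by these compounds, is whether chloro or methoxy behaves the same at the ring position held by the methyl of compound 3.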